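The compounds below may be only part of what the source reports. "The series", "measured", "known", "first", "only" and "open" are said of these compounds alone.

Compound 1, `O=C(NC1CCC(O)CC1)N1CCC(c2nc(-c3ccc4ccccc4n3)no2)CC1`, gives 2700 nM in a functional assay on Shh Light II cells (Mus musculus) for inhibition, read by a luciferase reporter; a lower number here means a stronger inhibitor, a higher number a weaker inhibitor.
Compound 2, `COc1ccccc1N(C)C(=O)N1CCC(c2nc(-c3ccc4ccccc4n3)no2)CC1`, gives 3100 nM.
Compound 3, `O=C(Nc1ccccc1C(F)(F)F)N1CCC(c2nc(-c3ccc4ccccc4n3)no2)CC1`, gives 700 nM.

Among these three, compound 1 stands second highest. Compound 2 sits within the scatter of it, a 1.1-fold higher number from compound 1 to compound 2 (0.06 log units; within the scatter), so the two cannot be told apart, while compound 3 lies clearly lower, a 3.9-fold lower number from compound 1 to compound 3 (0.59 log units; beyond the scatter). Compound 4, `Cc1ccccc1NC(=O)N1CCC(c2nc(-c3ccc4ccccc4n3)no2)CC1`, has not yet been measured in this assay. It differs from compound 1 in one place: 2-methylphenyl in place of 4-hydroxycyclohexyl on an amide-type nitrogen. The step that bears most directly on this replaced the same 4-hydroxycyclohexyl with 2-(trifluoromethyl)phenyl on the same amide-type nitrogen and gave a 3.9-fold lower number from compound 1 to compound 3 (0.59 log units; beyond the scatter). The other step ending in the same compound points the same way, a 4.4-fold lower number from compound 2 to compound 3 (0.65 log units; beyond the scatter). For the measured compounds named here, no measured step shows a 2-methylphenyl, so whether a methyl behaves like a trifluoromethyl here is unknown; a lower number, of similar or somewhat smaller size, is the likelier outcome. Compound 4 is therefore expected to give 1000 nM, with a range from 400 nM to 2500 nM. That estimate corresponds to an expected step of a 2.7-fold lower number from compound 1 to compound 4 (0.43 log units; beyond the scatter).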

Compound 4, half-maximal inhibitory concentration: 440 nM
The estimate for compound 4 lay 2.3-fold (0.36 log units) above the measured number; the range from low to high includes it.
By their numbers in this assay, from the lowest: compounds 4 and 3 (each within the scatter of the next); then compounds 1 and 2 (each within the scatter of the next).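

Putting 2-methylphenyl in place of 4-hydroxycyclohexyl on the amide-type nitrogen gives a clearly stronger inhibitor in this assay (a 6.1-fold lower number from compound 1 to compound 4 (0.79 log units; beyond the scatter)), and (2-methylphenyl)amino likewise outperforms the (2-methoxyphenyl)(methyl)amino of compound 2 (a 7.0-fold lower number from compound 2 to compound 4 (0.85 log units; beyond the scatter)). Compound 3 and compound 4 cannot be told apart (a 1.6-fold lower number from compound 3 to compound 4 (0.20 log units; within the scatter)), so the earlier drop in the number seen with compound 3 does not require a trifluoromethyl group: here, a methyl serves as well.

The compounds shown do not separate the contribution of the aromatic ring from that of the methyl or trifluoromethyl on it, which an unsubstituted phenyl on the same nitrogen could address. Nor do they show whether the hydroxyl matters, which a plain cyclohexyl could test, or how a chloro or ethyl group on the ring would compare. No supporting measurement is available to explain these steps.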